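The source may hold more compounds than are shown below. What is called first, only, known or untested is meant among the compounds shown, and "the series" means these compounds.

Compound 1 `CC(=O)OCc1cc2c(c(O)c1O)[C@H](C)C[C@@H](OC(C)=O)[C@H]2[C@@H](C)CCC=C(C)C` gives 80000 nM in an ADME assay on HEK293 cells (Homo sapiens) for inhibition, read by resazurin assay, with a stated time of 72 h; on this read-out lower numbers stand for stronger inhibition and higher numbers for weaker inhibition. Compound 2 `CC(C)=CCC[C@H](C)[C@H]1c2cc(C(=O)NCc3ccccc3)c(OC(=O)C(C)(C)C)c(OC(=O)C(C)(C)C)c2[C@H](C)C[C@H]1OC(=O)C(C)(C)C`, which carries a benzylamide and three pivalate groups on the shared core, gives 40000 nM in this assay, and compound 3 `CC(C)=CCC[C@H](C)[C@H]1c2cc(C(=O)NCc3ccc(Br)cc3)c(OC(=O)C(C)(C)C)c(OC(=O)C(C)(C)C)c2[C@H](C)C[C@H]1OC(=O)C(C)(C)C` gives 40000 nM in this assay. For the measured compounds named here, the one measured step, no change at the digits printed from compound 2 to compound 3 (within the scatter), adds a bromo in place of hydrogen on an aromatic carbon without moving the number. Compound 3 thus sits level with compound 2 at the digits shown, and the number for compound 1 lies within the scatter of both, so none of the three can be set apart from the others on these data.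

Compound 4 `CC(C)=CCC[C@H](C)[C@H]1c2cc(C(=O)NCc3ccc(Cl)cc3)c(OC(=O)C(C)(C)C)c(OC(=O)C(C)(C)C)c2[C@H](C)C[C@H]1OC(=O)C(C)(C)C` is the next step: chloro in place of bromo on an aromatic carbon. Going by the values given here, the only step that bears on this position, no change at the digits printed from compound 2 to compound 3 (within the scatter), showed that placing a bromo there against hydrogen changed nothing beyond the scatter; swapping one halogen for another at the same aromatic carbon is a smaller change than that, and no other measured pair informs it. Compound 4 is therefore expected to give 40000 nM in this assay, with a range from 20000 nM to 80000 nM. The expected step of no change at the digits printed from compound 3 to compound 4 (within the scatter) is estimated as none beyond the scatter.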

Compound 4, half-maximal inhibitory concentration: 40000 nM
The estimate for compound 4 equals the measured number at the digits printed; the range from low to high includes it.
By their numbers in this assay, from the lowest: compounds 2, 3, 4 and 1 (each within the scatter of the next).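

In this assay, the exchange of 4-bromophenyl for 4-chlorophenyl reads as a step with no visible effect (no change at the digits printed from compound 3 to compound 4 (within the scatter)), and the chloro set against hydrogen on the same aromatic carbon reads the same way (no change at the digits printed from compound 2 to compound 4 (within the scatter)). The earlier compounds had shown this for one halogen only, whereas hydrogen, bromo and chloro can now be compared at this place, para to a large group, and none of the three can be told from the others in this assay, so the lack of effect seen with bromo is not unique to that atom. No accompanying measurement bears on why the number stays the same at this position.

Going by these compounds, whether a group other than a halogen, such as a methoxy group, an amine, a carboxylic acid or a longer chain, would read differently on this aromatic carbon stays open. The benzylamides shown vary at this one carbon only, so it also stays open how the number would respond if the three pivalate groups gave way to acetates or free hydroxyl groups with the benzylamide kept.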